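This account rests on a few compounds, and the source may have more. Where it says the series, first, only, none or still open, it means among the compounds named here.

In a functional assay on K562 cells (Homo sapiens) for cytotoxicity, read by ELISA, with a stated time of 4 days; on this read-out lower numbers stand for stronger inhibition and higher numbers for weaker inhibition:
- compound 1 `Cc1ccsc1-c1cc(-c2ccoc2)cc(-c2ccco2)n1`: 23300 nM
- compound 2 `Clc1ccc(-c2cc(-c3ccoc3)cc(-c3ccco3)n2)s1`: 16200 nM

Among the compounds with values here, compound 2 stands within the scatter of compound 1, as the only measured step shows: a 1.4-fold lower number from compound 1 to compound 2 (0.16 log units; within the scatter). Compound 3 `Cc1ccccc1-c1cc(-c2ccoc2)cc(-c2ccc(Cl)s2)n1` has 2-methylphenyl in place of furan-2-yl on an aromatic carbon, next to the ring nitrogen: 2-methylphenyl in place of furan-2-yl on an aromatic carbon. Within the data shown here, compound 1 and compound 2 both carry furan-2-yl, so no measured step tests this change and the range stays wide. With no measured guide to a direction, no change beyond the scatter in this assay is expected: a 1.1-fold lower number from compound 2 to compound 3 (0.03 log units; within the scatter). Compound 3 is estimated at 15000 nM, with an expected range of 5000 nM to 45000 nM.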

Compound 3, half-maximal inhibitory concentration: 12300 nM
For compound 3 the middle estimate is 1.2-fold (0.09 log units) above the measured one, within the range that was stated.
By their numbers in this assay, from the lowest: compounds 3, 2 and 1 (each within the scatter of the next).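

In this assay, 2-methylphenyl in place of furan-2-yl next to the ring nitrogen gives a 1.3-fold lower number from compound 2 to compound 3 (0.12 log units; within the scatter) and so stays within the scatter. This position therefore takes a six-membered aromatic ring of carbon only, with no hydrogen-bond acceptor, without a change beyond the scatter. No evidence is available to explain this result.

Open, from the compounds shown here alone, is whether an amine or a carboxylic acid at this position, or a longer chain in place of the furan-3-yl group, moves the number beyond the scatter. Also open, going by these compounds, is whether this step holds with 3-methylthiophen-2-yl in place of 5-chlorothiophen-2-yl.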